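Methoxy for methyl on the anilide ring of compound 2

The compounds below may be only part of what the source reports. "The series", "measured", "known", "first", "only" and "open" are said of these compounds alone.

Measured compounds:
compound 1, `O=C(NN1CCOCC1)c1c(O)c2cccnc2n(-c2ccccc2)c1=O`, -8.5%
compound 2, `Cc1ccc(NC(=O)c2c(O)c3cccnc3n(-c3ccccc3)c2=O)cc1`, -3.5%

Both compounds were tested in a functional assay on the whole organism for inhibition, with Rattus norvegicus as the target, read by paw edema, at a dose of 100 mg/kg by the oral route; on this read-out lower numbers stand for less inhibition and higher numbers for more inhibition at the one dose given (going by the name of the read-out). Compound 1 gives -8.5% and compound 2 gives -3.5%; the change a number 5 percentage points higher from compound 1 to compound 2 (within the scatter) lies within the scatter, so the two numbers cannot be told apart. Compound 2 shows the higher of the two numbers, but only by a margin that repeated measurements would blur.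

Compound 3, `COc1ccc(NC(=O)c2c(O)c3cccnc3n(-c3ccccc3)c2=O)cc1`, has not been measured. It differs from compound 2 by methoxy in place of methyl on an aromatic carbon. For the measured compounds named here, no measured step touches this position: the only step available, from compound 1 to compound 2, concerns the group on the amide-type nitrogen and was itself within the scatter. The data therefore offer nothing that would point to a step beyond the scatter in this assay in either direction. Compound 3 is estimated at -4%, between -18% and 10%, which is expected to mean a step of a number 0.5 percentage points lower from compound 2 to compound 3 (within the scatter) of no consequence.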

Compound 3, a percentage reported as inhibition, in the whole organism at one dose (the size of the read-out at that dose, not a potency): 0.3%
Estimate against measurement, compound 3: 4.3 percentage points below, within the range that was stated.
By their numbers in this assay, from the lowest: compounds 1, 2 and 3 (each within the scatter of the next).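

In this assay, for the compounds shown here, this position, on an aromatic carbon para to a large group, is now tested directly for the first time: methoxy in place of methyl gives a number 3.8 percentage points higher from compound 2 to compound 3 (within the scatter), so this swap produces no step that can be told from the usual scatter. The step on the amide-type nitrogen, 4-methoxyphenyl in place of morpholin-4-yl, gives a number 8.8 percentage points higher from compound 1 to compound 3 (within the scatter), which leaves all three compounds within the scatter of one another. No separate measurement bears on this result.

The three compounds leave open whether any group at this place can produce a step beyond the scatter. An amine or a carboxylic acid in place of methoxy, or a longer chain such as ethoxy, would test this further.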